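Swapping the Ring Substituent on a Weakly Active Series

A few compounds are considered here, and "the series" means these few. Any claim that something is new, unique, unknown or untested is made for them only; others in the source may bear on it.

Compound 1 `Cc1cc(N2CC[C@@H](C)[C@@H](N(C)c3ncnc4[nH]ccc34)C2)n2nc(SCc3ccccc3Br)nc2n1` was tested in a functional assay on HGC-27 cells (Homo sapiens) for inhibition, read by MTT assay, with a stated time of 72 h (a higher number here means a weaker inhibitor, a lower number a stronger inhibitor), and gives 21300 nM. Compound 2 `Cc1cc(N2CC[C@@H](C)[C@@H](N(C)c3ncnc4[nH]ccc34)C2)n2nc(SCc3ccc([N+](=O)[O-])cc3)nc2n1` carries a 4-nitrophenyl group in place of the 2-bromophenyl and gives 29400 nM; the step of a 1.4-fold higher number from compound 1 to compound 2 (0.14 log units; within the scatter) is too small to separate the two. Compound 3 `Cc1cc(N2CC[C@@H](C)[C@@H](N(C)c3ncnc4[nH]ccc34)C2)n2nc(SCCCc3ccccc3)nc2n1` returned only a limit, > 100000 nM. That reading is the limit of > 100000 nM in this assay, at which 1 of the 3 values shown sits. Against it, an at least 4.6-fold higher number from compound 1 to compound 3 (0.67 log units; beyond the scatter) and an at least 3.4-fold higher number from compound 2 to compound 3 (0.53 log units; beyond the scatter), so compound 1 and compound 2 sit together as the two real numbers, both clearly ahead of compound 3.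

Compound 4 `COc1ccc(CSc2nc3nc(C)cc(N4CC[C@@H](C)[C@@H](N(C)c5ncnc6[nH]ccc56)C4)n3n2)cc1` is not yet measured. It differs from compound 1 by 4-methoxyphenyl in place of 2-bromophenyl on a saturated chain carbon bound to a sulfur. Among the measured compounds shown here, the closest precedent is the change from compound 1 to compound 2, which also kept the saturated chain carbon bound to a sulfur and altered only the substituent on the aromatic ring, and that step stayed within the scatter; only the phenethyl change leading to compound 3 moved the number beyond it. A similarly small shift is therefore expected for compound 4, a 1.2-fold higher number from compound 1 to compound 4 (0.07 log units; within the scatter). Compound 4 is estimated at 25000 nM, with a range from 10000 nM to 70000 nM.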

Compound 4, half-maximal inhibitory concentration: 18200 nM
Compound 4: middle estimate off by 1.4-fold (0.14 log units), on the high side, and the stated range covers the measured number.
By their numbers in this assay, from the lowest: compounds 4, 1 and 2 (each within the scatter of the next). At a limit, above all of these: compound 3.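

Moving to a third ring substituent still leaves the number in this assay unchanged within the scatter, with a 1.2-fold lower number from compound 1 to compound 4 (0.07 log units; within the scatter) and a 1.6-fold lower number from compound 2 to compound 4 (0.21 log units; within the scatter), so 2-bromophenyl, 4-nitrophenyl and 4-methoxyphenyl cannot be told apart on this saturated chain carbon bound to a sulfur, even though only 4-methoxyphenyl carries a hydrogen-bond acceptor. The separation from the phenethyl group now holds against a third compound, with an at least 5.4-fold lower number from compound 3 to compound 4 (0.73 log units; beyond the scatter). The reading for compound 3 is a limit, not a number: the limit of > 100000 nM in this assay, at which 1 of the 4 values shown sits.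

The compounds shown leave open whether an amine or a carboxylic acid on the aromatic ring would shift the number beyond the scatter. They also leave open what a plain phenyl or a pyridine ring would give at this position, with the rest of compound 1 kept the same.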